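Cytotoxicity limits in the series and a next analogue

The source may hold more compounds than are shown below. What is called first, only, known or untested is meant among the compounds shown, and "the series" means these compounds.

Measured in an ADME assay on Vero cells (Chlorocebus sabaeus) for cytotoxicity, read by MTT assay, with a stated time of 72 h; a higher number here means a weaker inhibitor, a lower number a stronger inhibitor:
compound 1 `CCn1cc(C(=O)N2N=C(c3cc4ccccc4o3)CC2c2ccccc2C(=O)O)c(=O)c2ccc(C)nc21`: > 196000 nM
compound 2 `CCn1cc(C(=O)N2N=C(c3cc4ccccc4o3)CC2c2ccccc2[N+](=O)[O-])c(=O)c2ccc(C)nc21`: > 85400 nM
compound 3 `CCn1cc(C(=O)N2N=C(c3cc4ccccc4o3)CC2c2ccco2)c(=O)c2ccc(C)nc21`: > 185000 nM

Every value shown is a limit, not a number. Compound 3 stands at such a limit, (the limit of > 185000 nM in this assay, at which 1 of the 3 values shown sits). The steps a step that the two limits leave unreadable from compound 1 to compound 2, a step that the two limits leave unreadable from compound 1 to compound 3 and a step that the two limits leave unreadable from compound 2 to compound 3 are therefore unreadable in this assay; nothing in them shows a direction.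

Compound 4 `CCn1cc(C(=O)N2N=C(c3cc4ccccc4o3)CC2/C=C/c2ccccc2)c(=O)c2ccc(C)nc21` carries the change (2-phenylethenyl in place of furan-2-yl on a saturated ring carbon). Among the measured compounds shown here, no measured step bears readably on it, so no direction beyond the scatter can be drawn from compound 1, compound 2 or compound 3. The step of an at least 1.2-fold lower number from compound 3 to compound 4 (0.09 log units; that floor lies within the scatter) is therefore estimated as none, and compound 4 is expected to report only a limit again, estimated at 150000 nM with a range from 50000 nM to 300000 nM.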

Compound 4, half-maximal inhibitory concentration: > 168000 nM
Compound 4: only a limit was reported; the forecaster's own chance of this, stated with the estimate: 80%; at least 1.1-fold (0.04 log units) between middle value and limit.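

In this assay, among the compounds shown here, compound 4 gives > 168000 nM, again a limit and not a number, so no step linking compound 4 with compound 1, compound 2 or compound 3 can be read. On these data alone, whether the group on the saturated ring carbon affects the result in this assay remains open.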